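A few compounds are considered here, and "the series" means these few. Any claim that something is new, unique, unknown or untested is made for them only; others in the source may bear on it.

Measured in an ADME assay on microsomes from liver (Mus musculus) for pharmacokinetics, read by LC-MS, using NADPH, with stated times of 5 min, 15 min and 30 min, tested at 10 uM; on this read-out lower numbers stand for slow clearance and higher numbers for fast clearance:
- compound 1 `CCC(=O)N[C@@H](C)c1ccc(NC(=O)N2CC(c3cccnc3)C2)cc1`: 31.4 mL.min-1.g-1
- compound 2 `C[C@H](NC(=O)c1cccc(F)c1)c1ccc(NC(=O)N2CC(c3cncc(N)c3)C2)cc1`: 27.4 mL.min-1.g-1

Compound 2, at 27.4 mL.min-1.g-1, stands within the usual scatter of compound 1, at 31.4 mL.min-1.g-1, so these two values cannot be told apart. The next compound, compound 3 `CCC(=O)N[C@@H](C)c1ccc(NC(=O)N2CC(c3cncc(N)c3)C2)cc1`, has ethyl in place of 3-fluorophenyl on a carbonyl carbon. Going by the values given here, no measured pair here differs in one place, so nothing shows directly what this change does in this assay. The expectation is therefore a small move toward a lower number, not beyond the scatter. The expected size is given by a 1.3-fold lower number from compound 2 to compound 3 (0.12 log units; within the scatter). Compound 3 is estimated at 21 mL.min-1.g-1, with an expected range of 10 mL.min-1.g-1 to 40 mL.min-1.g-1.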

Compound 3, intrinsic clearance in microsomes: 56.9 mL.min-1.g-1
The estimate for compound 3 lay 2.7-fold (0.43 log units) below the measured number; measured number outside the range, above it.
By their numbers in this assay, from the lowest: compounds 2, 1 and 3 (each within the scatter of the next, the first and the last beyond it).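

In this assay, going by these compounds alone, ethyl in place of 3-fluorophenyl on a carbonyl carbon gives the first step at this position that can be read directly (a 2.1-fold higher number from compound 2 to compound 3 (0.32 log units; beyond the scatter)), a modest rise in clearance that lies beyond the scatter. Amino in place of hydrogen on an aromatic carbon gives a smaller step (a 1.8-fold higher number from compound 1 to compound 3 (0.26 log units; within the scatter)) that stays within the scatter, so among these compounds only the change on the carbonyl carbon can be told apart from no change. Nothing measured here explains why the change on the carbonyl carbon moves clearance.

Going by these compounds, it remains open whether a longer chain such as butyl, or an unsubstituted phenyl, on that carbonyl carbon would sit nearer ethyl or 3-fluorophenyl. Also open, on these data alone, is whether the step keeps its size with hydrogen or a methoxy group in place of the amino group.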